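Chloro-to-hydrogen step in a leukemia cytotoxicity series

The source may report more compounds than this note shows. Statements on the series, on what has been measured and on what is new or still open speak of the compounds shown alone.

Measured so far:
Compound 1 `COc1c(/C=C2/C(=O)Nc3ccc(Cl)cc32)c2ccccc2n1-c1ccccc1`: 8910 nM
Compound 2 `COc1cc2c(/C=C3/C(=O)Nc4cccc(Cl)c43)c(Cl)n(Cc3cc(OC)c(OC)c(OC)c3)c2cc1C`: 14100 nM

In a functional assay on cells (Leukemia cell, Homo sapiens) for cytotoxicity, with a stated time of 48 h (a lower number here means a stronger inhibitor of growth, a higher number a weaker inhibitor of growth), compound 1 gives 8910 nM, the lowest of the two numbers; compound 2 gives 14100 nM, which is within the scatter of compound 1, so no order between them is drawn. Compound 3 `COc1c(/C=C2/C(=O)Nc3ccccc32)c2ccccc2n1-c1ccccc1` is not yet measured and differs from compound 1 by hydrogen in place of chloro on an aromatic carbon. Among the compounds with values here, no measured pair isolates this change, so the expected step of a 1.3-fold higher number from compound 1 to compound 3 (0.13 log units; within the scatter) is small, none beyond the scatter. Compound 3 is expected at 12000 nM, with a range of 4000 nM to 35000 nM.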

Compound 3, concentration for total growth inhibition: 2630 nM
Compound 3: the middle estimate sits 4.6-fold (0.66 log units) above what was measured, outside the stated range (below it).
By their numbers in this assay, from the lowest: compound 3; then compounds 1 and 2 (each within the scatter of the next).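

In this assay, within the data shown here, replacing chloro with hydrogen on this aromatic carbon gives a 3.4-fold lower number from compound 1 to compound 3 (0.53 log units; beyond the scatter) and is the first step that isolates one position. At this carbon of the core of compound 1, the chloro is therefore not required for growth inhibition, and the number is lower with hydrogen. No available evidence accounts for the step.

From the compounds shown here alone, whether an amine, a carboxylic acid or a fluoro group on this carbon would track hydrogen or chloro remains open. Also open, going by these compounds, is whether the same change would have a similar effect in compound 2.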